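This account rests on a few compounds, and the source may have more. Where it says the series, first, only, none or still open, it means among the compounds named here.

Notes on the sulfonyl series, read in a functional assay on K562 cells (Homo sapiens) for inhibition, read by trypan blue exclusion, with a stated time of 72 h; a higher number here means a weaker inhibitor, a lower number a stronger inhibitor. Compound 1 (`Cn1c(=O)c(S(=O)(=O)c2ccc(Cl)cc2Cl)cc2cnc(Nc3ccc4[nH]ccc4c3)nc21`) gives 1000 nM, and compound 2 (`Cn1c(=O)c(S(=O)(=O)Cc2ccc(F)cc2F)cc2cnc(Nc3ccc4[nH]ccc4c3)nc21`) gives 1000 nM. Between these two there is no change at the digits printed from compound 1 to compound 2 (within the scatter). Compound 3 (`Cn1c(=O)c(S(=O)(=O)c2ccc(Br)cc2)cc2cnc(Nc3ccc4[nH]ccc4c3)nc21`) gives 5000 nM, the highest of the three numbers, which makes it the weakest inhibitor measured so far.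

Compound 4 (`Cn1c(=O)c(S(=O)(=O)Nc2ccc(F)cc2F)cc2cnc(Nc3ccc4[nH]ccc4c3)nc21`) has not been measured. It carries (2,4-difluorophenyl)amino in place of 4-bromophenyl on a sulfonyl sulfur.

Two measured steps change this same place: a 5.0-fold higher number from compound 1 to compound 3 (0.70 log units; beyond the scatter), and a 5.0-fold higher number from compound 2 to compound 3 (0.70 log units; beyond the scatter). Both are modest and both end on the 4-bromophenyl group, so leaving that group has some support for a return toward the lower numbers. Within the data shown here, the entering group most resembles the one on compound 2, which stands at 1000 nM. Among the measured compounds shown here, no measured compound has an amino link on the sulfonyl sulfur, however, and the data do not show what that link does. A lower number is therefore expected, but with less confidence than the measured steps alone would suggest. The expected change is a 3.3-fold lower number from compound 3 to compound 4 (0.52 log units; beyond the scatter). For compound 4 the estimate is 1500 nM, with an expected range of 400 nM to 5000 nM.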

Compound 4, half-maximal inhibitory concentration: 5000 nM
The estimate for compound 4 lay 3.3-fold (0.52 log units) below the measured number; measured number inside the range.
By their numbers in this assay, from the lowest: compounds 1 and 2 (each within the scatter of the next); then compounds 3 and 4 (each within the scatter of the next).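

In this assay the step to (2,4-difluorophenyl)amino on the sulfonyl sulfur shows no change at the digits printed from compound 3 to compound 4 (within the scatter) and so gives no return toward the lower numbers on leaving 4-bromophenyl. Against the other two groups the same entering group shows a 5.0-fold higher number from compound 2 to compound 4 (0.70 log units; beyond the scatter) and a 5.0-fold higher number from compound 1 to compound 4 (0.70 log units; beyond the scatter) at this position, so the 2,4-difluorinated ring shared by compound 2 and compound 4 does not by itself keep the lower number, and the two groups differ in how that ring is linked to the sulfur. No measurement beyond these numbers offers an explanation for this.

The amino link appears only with the 2,4-difluorinated ring, and 2,4-dichlorophenyl and 4-bromophenyl appear only directly on the sulfur, so the compounds shown do not separate the effect of the link from that of the ring's halogens. Also open, as far as these compounds go, is how this position reads with a group lacking an aromatic ring altogether, such as a plain methyl group, a longer alkyl chain or a morpholine ring.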